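The source may report more compounds than this note shows. Statements on the series, on what has been measured and on what is new or still open speak of the compounds shown alone.

Working notes on the series.

Within the data shown here, compound 1, `Nc1nc(=O)ccn1[C@@H]1O[C@H](COP(=O)(O)OP(=O)(O)O)[C@@H](O)[C@H]1O`, is the only member of the series with a number in an in vitro functional assay on 1321-N1 cells for agonist activity at P2Y purinoceptor 2 (Homo sapiens), read by scintillation proximity assay and inositol phosphate accumulation; a higher number here means that more compound is needed for the effect, a lower number that less compound is needed; in this assay compound 1 gives 604 nM. Compound 3, `Nc1nc(=O)ccn1[C@@H]1O[C@H](COP(=O)(O)O)[C@@H](O)[C@H]1O`, sits at a limit of this assay, with compound 3 reported at > 100000 nM. Compound 2, `O=c1[nH]c(=S)ccn1[C@@H]1O[C@H](COP(=O)(O)O)[C@@H](O)[C@H]1O`, likewise sits at a limit, with compound 2 reported at > 100000 nM. Among the measured compounds shown here, the one measured step that carries a number is an at least 160-fold higher number from compound 1 to compound 3 (2.21 log units; beyond the scatter), and the limit of > 100000 nM in this assay, at which 2 of the 3 values shown sit, marks where compounds 2 and 3 rest.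

Compound 4, `O=c1ccn([C@@H]2O[C@H](COP(=O)(O)OP(=O)(O)O)[C@@H](O)[C@H]2O)c(SCc2ccccc2)n1`, keeps the diphosphate of compound 1 and changes the base: benzylsulfanyl in place of amino on an aromatic carbon, on an aromatic carbon of a six-membered aromatic ring with two nitrogen, between two ring nitrogen atoms, ortho to a large group, meta to a group of one heavy atom. For the measured compounds named here, no measured step touches this position; the only measured step, from compound 1 to compound 3, concerns the phosphate chain, which compound 4 retains. Going by the values given here, the step into compound 4 is therefore a new variable with no precedent, and the expectation for compound 4 in this assay rests on retention of the diphosphate rather than on any measured analogue. The step is expected as a 2.5-fold higher number from compound 1 to compound 4 (0.40 log units; beyond the scatter), with compound 4 estimated at 1500 nM, within 150 nM to 15000 nM.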

Compound 4, half-maximal effective concentration: 6200 nM
For compound 4 the middle estimate is 4.1-fold (0.62 log units) below the measured one; measured number inside the range.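

The position between two ring nitrogen atoms now has a measured step of its own: benzylsulfanyl in place of amino on an aromatic carbon gives a 10-fold higher number from compound 1 to compound 4 (1.01 log units; beyond the scatter), so in this assay the number depends on the base as well as on the phosphate chain. The amino group is therefore not indispensable for a measurable response, since compound 4 lacks it and, with the diphosphate kept, still returns a value despite the much larger group that enters, carrying a six-membered aromatic ring of carbon only. Even so, the swap costs potency well beyond the scatter, yet compound 4 stays clear of the ceiling that holds the two shorter-chain compounds: the limit of > 100000 nM in this assay, at which 2 of the 4 values shown sit.

With only amino and benzylsulfanyl shown at this position, the compounds leave open whether the step follows the sulfur link or the benzyl ring, which methylsulfanyl or a longer phenethylsulfanyl chain would help to separate. Also open, as far as these compounds go, is whether a chlorine atom or a methoxy group on the benzyl ring would move the number in either direction.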